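The source may hold more compounds than are shown below. What is called first, only, known or untested is meant among the compounds shown, and "the series" means these compounds.

In a functional assay on HepG2 cells (Homo sapiens) for cytotoxicity, read by CCK-8 assay (a higher number here means a weaker inhibitor, a lower number a stronger inhibitor), compound 1 (`COc1ccc(NC(=O)c2ncc(-c3cc(OC)c(OC)c(OC)c3)o2)cc1`) gives > 30000 nM as its reading, which is a limit of the assay and not a number. Compound 2 (`O=C(Nc1cccc(O)c1)c1ncc(-c2ccccc2)o1`) gives > 30000 nM as its reading, and this is also a limit. Compound 3 (`COc1ccc(NC(=O)c2ncc(-c3ccccc3)o2)cc1`) gives > 30000 nM as its reading, again a limit. The whole record so far is the limit of > 30000 nM in this assay, at which 3 of the 3 values shown sit, and so compound 3 has no exact place, and the three compounds cannot be ranked against one another.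

Compound 4 (`CCN(CC)c1ccc(NC(=O)c2ncc(-c3ccccc3)o2)cc1`) differs from compound 3 in one place: diethylamino in place of methoxy on an aromatic carbon, para to a large group (diethylamino in place of methoxy on an aromatic carbon). Among the measured compounds shown here, this swap brings a larger group, but the measurements so far offer no step that shows what such a change does in this assay to guide the estimate.

No step beyond the usual scatter is expected, since compound 3 reads > 30000 nM and gives no sign of activity to build on. If a number does appear, it is expected on the stronger side of that limit. The expected change an at least 1.0-fold lower number from compound 3 to compound 4 (0.02 log units; that floor lies within the scatter) is small. For compound 4 the estimated value is 28000 nM within a range of 10000 nM to 60000 nM and the assay may well report only a limit again.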

Compound 4, half-maximal inhibitory concentration: > 30000 nM
Compound 4 gave a limit, no number (the forecaster's own chance of this, stated with the estimate: 70%); middle value at least 1.0-fold (0.02 log units) away from the limit.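

No step can be read from compound 3 to compound 4, since neither reading is an exact number and the record holds only this limit: the limit of > 30000 nM in this assay, at which 4 of the 4 values shown sit. The compounds shown leave open whether any change to the shared core gives an exact reading in this assay at all, and how these four would rank against one another.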